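Amino to benzylsulfanyl on the shared core: expecting a limit

This account rests on a few compounds, and the source may have more. Where it says the series, first, only, none or still open, it means among the compounds named here.

Compound 1, `Nc1nnc(-c2ccccc2OCc2ccccc2)o1`: 85.2 mg/kg
Compound 2, `Nc1nnc(-c2ccccc2OCc2ccc(Cl)cc2)o1`: a limit of the assay, > 100 mg/kg
Compound 3, `CCSc1nnc(-c2ccccc2OCc2ccccc2)o1`: a limit of the assay, > 100 mg/kg

Within the data shown here, in a functional assay on the whole organism with Mus musculus as the target (on this read-out lower numbers stand for an effect already at smaller amounts and higher numbers for an effect only at larger amounts of compound), compound 1 gives 85.2 mg/kg, the only plain number among the three. Compound 2 reaches only the limit of the assay, > 100 mg/kg. Compound 3 likewise reaches only the limit, > 100 mg/kg. Compound 1 thus stands alone with a measured dose, while the other two sit at the limit of > 100 mg/kg in this assay, at which 2 of the 3 values shown sit.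

Compound 4, `c1ccc(COc2ccccc2-c2nnc(SCc3ccccc3)o2)cc1`, differs from compound 1 in one place: benzylsulfanyl in place of amino on an aromatic carbon. The step that bears on this is an at least 1.1-fold higher number from compound 1 to compound 3 (0.06 log units; that floor lies within the scatter), which exchanges the same amino for ethylsulfanyl on the same carbon; the step of an at least 1.1-fold higher number from compound 1 to compound 2 (0.06 log units; that floor lies within the scatter) touches another part of the molecule. Both ended at the limit. For compound 4 a higher number in this assay is therefore expected. The expected step is a 1.9-fold higher number from compound 1 to compound 4 (0.27 log units; within the scatter). For compound 4 the estimate is 160 mg/kg, with a range from 60 mg/kg to 400 mg/kg.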

Compound 4, dose for half-maximal effect: > 100 mg/kg
Compound 4 gave a limit, no number; the forecaster's own chance of this, stated with the estimate: 70%; the middle value is on the limit's open side.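

With compound 4, a second group joined to this carbon through sulfur, now one carrying an aromatic ring, gives no plain dose in this assay, only an at least 1.1-fold higher number from compound 1 to compound 4 (0.06 log units; that floor lies within the scatter). On these data alone, the true size of this change therefore stays unknown, and the step between compound 3 and compound 4 cannot be read, since both values are limits. The limit now holds most of the series: the limit of > 100 mg/kg in this assay, at which 3 of the 4 values shown sit.

As far as these compounds go, whether any other group on this carbon, such as methylamino or hydroxyl, would give a plain dose stays open.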